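Adding a second methyl to the aryl amine

A few compounds are considered here, and "the series" means these few. Any claim that something is new, unique, unknown or untested is made for them only; others in the source may bear on it.

Measured so far:
compound 1 `O=C1C(Nc2ccccc2F)=CC(=O)c2c1nc1n2[C@H]2OC[C@@H](O)[C@H]2OC1` gives 9820 nM
compound 2 `O=C1C(Nc2ccc(Br)cc2)=CC(=O)c2c1nc1n2[C@H]2OC[C@@H](O)[C@H]2OC1` gives 5220 nM
compound 3 `Cc1ccc(NC2=CC(=O)c3c(nc4n3[C@H]3OC[C@@H](O)[C@H]3OC4)C2=O)cc1` gives 6590 nM

In a functional assay on HeLa cells (Homo sapiens) for inhibition, read by sulforhodamine B assay (a higher number here means a weaker inhibitor, a lower number a stronger inhibitor), compound 1 carries the highest of the three numbers, yet both others sit within the usual scatter of it: a 1.5-fold lower number from compound 1 to compound 3 (0.17 log units; within the scatter) and a 1.9-fold lower number from compound 1 to compound 2 (0.27 log units; within the scatter). Compound 4 `Cc1ccc(NC2=CC(=O)c3c(nc4n3[C@H]3OC[C@@H](O)[C@H]3OC4)C2=O)cc1C` has not been measured; the change from compound 1 is 3,4-dimethylphenyl in place of 2-fluorophenyl on an amine nitrogen. The two steps from compound 1 bear on this: replacing 2-fluorophenyl by 4-methylphenyl or by 4-bromophenyl each gave only a small lowering that stayed within the scatter, and compound 3 already carries one methyl, so adding a second is expected to move the number little. For compound 4 the expected step is a 1.8-fold lower number from compound 1 to compound 4 (0.25 log units; within the scatter), a small lowering within the scatter. Compound 4 is therefore estimated at 5500 nM, with a range from 2500 nM to 12000 nM.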

Compound 4, half-maximal inhibitory concentration: 4320 nM
Beside the measured number, compound 4's estimate is 1.3-fold (0.10 log units) above it; the range from low to high includes it.
By their numbers in this assay, from the lowest: compounds 4, 2, 3 and 1 (each within the scatter of the next, the first and the last beyond it).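

In this assay, for the compounds shown here, 3,4-dimethylphenyl is the only group on the amine nitrogen whose step away from 2-fluorophenyl clears the usual scatter (a 2.3-fold lower number from compound 1 to compound 4 (0.36 log units; beyond the scatter)). That does not single out the second methyl, since the step that adds it stays within the scatter (a 1.5-fold lower number from compound 3 to compound 4 (0.18 log units; within the scatter)), and 3,4-dimethylphenyl cannot be told apart from 4-bromophenyl (a 1.2-fold lower number from compound 2 to compound 4 (0.08 log units; within the scatter)). No measurement shown here explains the difference from 2-fluorophenyl.

Still open, as far as these compounds go, is how the number would respond to a methoxy group, a carboxylic acid or an amine on this aromatic ring.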